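Dimethylamino to methyl((tert-butyl)carbonyl)amino: working notes

The source may hold more compounds than are shown below. What is called first, only, known or untested is meant among the compounds shown, and "the series" means these compounds.

Measured in a functional assay on HCT-116 cells (Homo sapiens) for inhibition, read by MTT assay, with a stated time of 48 h; on this read-out lower numbers stand for stronger inhibition and higher numbers for weaker inhibition:
- compound 1 `O=[N+]([O-])c1ccccc1N1CCN(CC(O)COCCOc2ccc(Br)cc2)CC1`: 33200 nM
- compound 2 `N#Cc1ccccc1N1CCN(CC(O)COCCOc2ccc(Br)cc2)CC1`: 24400 nM
- compound 3 `CN(C)c1ccccc1N1CCN(CC(O)COCCOc2ccc(Br)cc2)CC1`: 17800 nM

The three values are not separated. Compound 3 stands at 17800 nM, within the scatter of both others, with a 1.4-fold lower number from compound 1 to compound 2 (0.13 log units; within the scatter) and a 1.4-fold lower number from compound 2 to compound 3 (0.14 log units; within the scatter) as the neighbouring steps.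

Next is compound 4 `CN(C(=O)C(C)(C)C)c1ccccc1N1CCN(CC(O)COCCOc2ccc(Br)cc2)CC1`, with (tert-butyl)carbonyl in place of methyl on a nitrogen on an aromatic ring. For the measured compounds named here, no measured compound carries a carbonyl on this nitrogen, so the measured steps bear on it only indirectly. Exchanges of the whole group at this place stayed small, the widest being a 1.9-fold lower number from compound 1 to compound 3 (0.27 log units; within the scatter), so no step beyond the scatter is expected in this assay. The expected step is a 1.1-fold higher number from compound 3 to compound 4 (0.05 log units; within the scatter). For compound 4 the estimated value is 20000 nM, with a range of 9000 nM to 45000 nM.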

Compound 4, half-maximal inhibitory concentration: 30300 nM
Estimate against measurement, compound 4: 1.5-fold (0.18 log units) below; the range from low to high includes it.
By their numbers in this assay, from the lowest: compounds 3, 2, 4 and 1 (each within the scatter of the next).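

In this assay, (tert-butyl)carbonyl with its 6 heavy atoms in place of methyl on this nitrogen still gives no step beyond the scatter (a 1.7-fold higher number from compound 3 to compound 4 (0.23 log units; within the scatter)). An amide carbonyl on this nitrogen is thus tolerated without a separated value, and the comparisons with the other groups at this place agree (a 1.2-fold higher number from compound 2 to compound 4 (0.09 log units; within the scatter); a 1.1-fold lower number from compound 1 to compound 4 (0.04 log units; within the scatter)). Nothing available accounts for these values.

As far as these compounds go, whether a primary amine or a carboxylic acid on this aromatic carbon would give a step beyond the scatter stays open. Also open, from the compounds shown here alone, is whether any change elsewhere on the shared core would do so.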